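Pentyl Gives Way to 2-Methoxyethoxy on a Long Chain

The source may report more compounds than this note shows. Statements on the series, on what has been measured and on what is new or still open speak of the compounds shown alone.

Of the compounds shown here, three have so far been measured in a physicochemical assay for solubility, at pH 6.8 (a lower number here means a less soluble compound, a higher number a more soluble compound), and the piece follows the one with the long saturated chain. Compound 3 `CCCCCCCCCc1[nH]c2ccccc2c(=O)c1C` returns < 1000 nM as its result, which is a limit and not a number. Compound 1 `CCCCOc1cccc(OCc2[nH]c3ccccc3c(=O)c2C)c1` returns < 1000 nM as its result, and this too is a limit. Compound 2 `O=c1c(Cl)c(COc2cccc(OCC3CCOCC3)c2)[nH]c2ccccc12` returns 2000 nM as a true number, the only one available. Among the measured compounds shown here, the measurements so far therefore show the limit of < 1000 nM in this assay, at which 2 of the 3 values shown sit, and no pair of measured compounds differs in just one place.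

Compound 4 `COCCOCCCCc1[nH]c2ccccc2c(=O)c1C` is next in line. The change is 2-methoxyethoxy in place of pentyl on a saturated chain carbon, four bonds along the chain from an aromatic carbon and in words it places 2-methoxyethoxy in place of pentyl on a saturated chain carbon, four bonds along the chain from an aromatic carbon.

For the measured compounds named here, with compound 2 at 2000 nM as the only number to lean on, a modest rise in this assay is expected, and it may not clear the usual scatter by much. The estimated step is an at least 1.5-fold higher number from compound 3 to compound 4 (0.17 log units; that floor lies within the scatter) and it starts from a limit, so it is uncertain. In this assay the estimate for compound 4 is 1500 nM with an expected range of 500 nM to 8000 nM until the measurement arrives.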

Compound 4, solubility: >= 100000 nM
Compound 4: no number, only a limit (the forecaster's own chance of this, stated with the estimate: 45%); at least 66-fold (1.82 log units) between middle value and limit.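

Among the compounds shown here, on a saturated chain carbon, four bonds along the chain from an aromatic carbon, putting 2-methoxyethoxy in place of pentyl gives an at least 100-fold higher number from compound 3 to compound 4 (2.00 log units; beyond the scatter) in this assay, and this is the first comparison here between compounds that differ in one place. The two groups each have 5 heavy atoms, so the step does not come with a change in the size of the group: 2 oxygen atoms enter, and the count of hydrogen-bond acceptors in the group goes from 0 to 2. Both ends of the step are limits and not numbers, so it gives only a floor for the true difference: the limit of >= 100000 nM in this assay, at which 1 of the 4 values shown sits.

The compounds shown do not tell whether both oxygen atoms are needed for a step of this size, or whether an amine or a carboxylic acid on the same chain carbon would give a similar result. They also leave open whether the same change would carry over to a compound with a different side chain on the shared core, such as compound 1 or compound 2.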